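The source may hold more compounds than are shown below. What is called first, only, known or untested is meant among the compounds shown, and "the series" means these compounds.

Compound 1, `CC(O)(C(=O)Nc1ccc(S(=O)(=O)c2ccc(C#N)cc2)cc1)C(F)(F)F`, gives in a functional assay (Cavia porcellus) with sulfonylurea receptors; K-ATP channels (Homo sapiens) as the target (a lower number here means a stronger inhibitor, a higher number a weaker inhibitor), a limit of the assay, > 30000 nM.
Compound 2, `CN(c1ccccc1)S(=O)(=O)c1ccc(NC(=O)C(C)(O)C(F)(F)F)cc1`, gives in this assay the value 2000 nM.
Compound 3, `CC(O)(C(=O)Nc1ccc(S(=O)(=O)c2cccnc2)cc1)C(F)(F)F`, gives in this assay the value 3500 nM.

Among the two plain numbers, compound 3 has the higher one, and compound 2 is its nearest neighbour; the step of a 1.8-fold higher number from compound 2 to compound 3 (0.24 log units; within the scatter) stays within the scatter, so the two cannot be ranked. The third value is not a number but a limit: compound 1 sits at the limit of > 30000 nM in this assay, at which 1 of the 3 values shown sits.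

Compound 4, `CC(O)(C(=O)Nc1ccc(S(=O)(=O)c2cncs2)cc1)C(F)(F)F`, has not yet been measured. It differs from compound 3 by a single change, (1,3-thiazol-5-yl in place of pyridin-3-yl on a sulfonyl sulfur). For the measured compounds named here, two measured steps concern this same place. The first, an at least 15-fold lower number from compound 1 to compound 2 (1.17 log units; beyond the scatter), and the second, an at least 8.5-fold lower number from compound 1 to compound 3 (0.93 log units; beyond the scatter), were both large, but each starts from a limit. The exchange of one aromatic group for another between the two measured numbers, a 1.8-fold higher number from compound 2 to compound 3 (0.24 log units; within the scatter), lay within the scatter. Replacing one small aromatic ring by another at this place is therefore expected to give no step beyond the scatter in this assay.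

Compound 4 is thus estimated at 4000 nM, with a range from 1500 nM to 12000 nM. The expected step is a 1.1-fold higher number from compound 3 to compound 4 (0.06 log units; within the scatter).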

Compound 4, half-maximal inhibitory concentration: 7700 nM
The estimate for compound 4 lay 1.9-fold (0.28 log units) below the measured number; low and high end bracket the measured number.
By their numbers in this assay, from the lowest: compounds 2 and 3 (each within the scatter of the next); then compound 4. At a limit, above all of these: compound 1.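

The exchange of one aromatic ring for another on the sulfonyl sulfur is not always silent in this assay: 1,3-thiazol-5-yl in place of pyridin-3-yl, a five-membered ring for a six-membered one, gives a 2.2-fold higher number from compound 3 to compound 4 (0.34 log units; beyond the scatter), and in place of methyl(phenyl)amino it gives a 3.9-fold higher number from compound 2 to compound 4 (0.59 log units; beyond the scatter). Against 4-cyanophenyl, the same ring still gives an at least 3.8-fold lower number from compound 1 to compound 4 (0.59 log units; beyond the scatter), so this position separates compounds over a wider span than the earlier values alone showed. Compound 1 itself stands at a limit: the limit of > 30000 nM in this assay, at which 1 of the 4 values shown sits.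

The compounds shown leave open how a saturated ring such as piperidine, or a plain dimethylamino group, on the sulfonyl sulfur would compare. Nothing here separates the effect of ring size from that of the kind of hetero atom in the step to 1,3-thiazol-5-yl.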